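The compounds below may be only part of what the source reports. "The series", "measured", "known", "first", "only" and "open" are said of these compounds alone.

Of the compounds shown here, three with a shared core have been tested in a functional assay on SiHa cells (Homo sapiens) for inhibition, read by CCK-8 assay, with a stated time of 72 h, tested at 10 uM; on this read-out lower numbers stand for less inhibition of growth and higher numbers for more inhibition of growth at the one concentration tested. Compound 1 `CN(C)C(=O)c1cc2cnc(Nc3ccc(NC(=O)C4(C(=O)Nc5cccc(F)c5)CC4)cc3)nc2n1C1CCCC1` gives 107%, compound 2 `CN(C)C(=O)c1cc2cnc(Nc3ccc(NC(=O)C4(C(=O)Nc5cccc(Cl)c5)CC4)cc3)nc2n1C1CCCC1` gives 97.3%, and compound 3 `CN(C)C(=O)c1cc2cnc(Nc3ccc(NC(=O)C4(C(=O)Nc5ccc(Cl)c(C(F)(F)F)c5)CC4)cc3)nc2n1C1CCCC1` gives 61.1%, the lowest of the three numbers. The first pair differs little, with a number 9.7 percentage points lower from compound 1 to compound 2 (within the scatter).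

Compound 4 `CN(C)C(=O)c1cc2cnc(Nc3ccc(NC(=O)C4(C(=O)Nc5ccccc5)CC4)cc3)nc2n1C1CCCC1` has not yet been measured. It differs from compound 3 in one place, on an amide-type nitrogen, where phenyl stands in place of 4-chloro-3-(trifluoromethyl)phenyl: phenyl in place of 4-chloro-3-(trifluoromethyl)phenyl on an amide-type nitrogen.

Among the measured compounds shown here, two measured steps bear on this change: a number 45.9 percentage points lower from compound 1 to compound 3 (beyond the scatter) and a number 36.2 percentage points lower from compound 2 to compound 3 (beyond the scatter). Both are large, and both lead to the group that compound 4 gives up. For the measured compounds named here, removing it should therefore move the number upward, though no tested compound carries a plain phenyl, so the size remains uncertain. The expected change is a number 26.9 percentage points higher from compound 3 to compound 4 (beyond the scatter), somewhat smaller than those two measured steps. The estimated value for compound 4 is 88%, with an expected range from 62% to 112%.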

Compound 4, percent growth inhibition at one concentration: 106%
Estimate against measurement, compound 4: 18 percentage points below, within the range that was stated.
By their numbers in this assay, from the lowest: compound 3; then compounds 2, 4 and 1 (each within the scatter of the next).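

In this assay, cutting the 4-chloro-3-(trifluoromethyl)phenyl back to plain phenyl on the amide-type nitrogen gives a number 44.9 percentage points higher from compound 3 to compound 4 (beyond the scatter) and so restores the high number; the low number of compound 3 therefore goes with what that group adds to the ring, not with the aromatic ring itself, which both compounds carry. The bare ring also stands level with the rings holding a single halogen, with a number 8.7 percentage points higher from compound 2 to compound 4 (within the scatter) and a number 1 percentage points lower from compound 1 to compound 4 (within the scatter) as the two steps, so here a lone chloro or fluoro reads no differently from hydrogen. Nothing in the available data explains these results.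

Among the compounds shown here, compound 3 carries chloro and trifluoromethyl together, so it stays open which of the two, or only the pair, goes with the lower number. As far as these compounds go, how a ring bearing an amine or a carboxylic acid would read also stays open.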